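A Bromophenyl Group Replaces the Pyridyl on the Triazole

The source may report more compounds than this note shows. Statements on the series, on what has been measured and on what is new or still open speak of the compounds shown alone.

Compound 1 `Cc1c(O)ccc2c1[C@H](Cn1cc(-c3ccccc3)nn1)[C@@]13CC(=O)[C@@](C)(CC[C@@H]21)C3`: > 20000 nM
Compound 2 `C=C1C(=O)[C@]23C[C@@]1(O)CC[C@H]2c1ccc(OS(=O)(=O)c2ccc(C)cc2)c(C)c1[C@@H]3Cn1cc(-c2ccccn2)nn1`: 320 nM
Compound 3 `C=C1C(=O)[C@]23C[C@@]1(O)CC[C@H]2c1ccc(O)c(C)c1[C@@H]3Cn1cc(-c2ccccn2)nn1`: 2240 nM

Going by the values given here, in a functional assay on MCF7 cells (Homo sapiens) for cytotoxicity, read by MTT assay, with a stated time of 4 days (on this read-out higher numbers stand for weaker inhibition and lower numbers for stronger inhibition), compound 3 gives 2240 nM, the highest of the two numbers measured so far. Its nearest neighbour is compound 2 at 320 nM, separated from it by the step of a 7.0-fold higher number from compound 2 to compound 3 (0.85 log units; beyond the scatter), which concerns the oxygen on the aromatic ring. For compound 1 the result is only a limit, > 20000 nM (the limit of > 20000 nM in this assay, at which 1 of the 3 values shown sits).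

Compound 4 `C=C1C(=O)[C@]23C[C@@]1(O)CC[C@H]2c1ccc(O)c(C)c1[C@@H]3Cn1cc(-c2ccc(Br)cc2)nn1` differs from compound 3 in one place: 4-bromophenyl in place of pyridin-2-yl on an aromatic carbon. Among the compounds with values here, no measured step touches this part of the molecule. Compound 1 also carries a phenyl on its triazole, but its core differs from that of compound 3 in several further places, so the two cannot be compared one change at a time. Within the data shown here, with no step of the same kind to draw on, the change is expected to move the number only modestly, if at all, giving an expected step of a 1.3-fold higher number from compound 3 to compound 4 (0.13 log units; within the scatter). In this assay compound 4 is therefore estimated at 3000 nM, with a likely range from 800 nM to 12000 nM.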

Compound 4, half-maximal inhibitory concentration: 270 nM
Compound 4: the middle estimate sits 11-fold (1.05 log units) above what was measured, and the stated range ends above it.
By their numbers in this assay, from the lowest: compounds 4 and 2 (each within the scatter of the next); then compound 3. At a limit, above all of these: compound 1.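

In this assay, replacing pyridin-2-yl with 4-bromophenyl on the triazole gives an 8.3-fold lower number from compound 3 to compound 4 (0.92 log units; beyond the scatter). Going by these compounds alone, the only earlier step, a 7.0-fold higher number from compound 2 to compound 3 (0.85 log units; beyond the scatter), concerned the oxygen on the aromatic ring, so this is the first sign that the group on the triazole also moves the number, with the rest of the molecule unchanged. Nothing measured here explains why this swap lowers the number.

The step removes a ring nitrogen and adds a bromine together, so the compounds shown cannot tell which of the two matters, or whether both do. A 4-chlorophenyl or a 4-methoxyphenyl on the same triazole would show whether bromine itself is needed or whether other groups at that spot on the phenyl ring serve as well.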